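Methoxy for Bromo on the Pyridine Amide

The source may report more compounds than this note shows. Statements on the series, on what has been measured and on what is new or still open speak of the compounds shown alone.

Two compounds have been measured in an in vivo ADME assay on the whole organism (strain Mongrel) for metabolic stability, with Canis familiaris (Canis lupus familiaris) as the target; on this read-out lower numbers stand for a shorter-lived compound and higher numbers for a longer-lived compound:
Compound 1 `C[C@@H](NC(=O)C1(NC(=O)c2cncc(Br)c2)CC1)c1ccc(-n2nc(Cl)c3ccccc32)cc1F`: 7.6 h
Compound 2 `C[C@@H](NC(=O)C1(NC(=O)c2cncs2)CC1)c1ccc(-n2nc(Cl)c3ccccc32)cc1F`: 4.3 h

Compound 1 stands highest of the two numbers. Going by the values given here, the single measured step is a 1.8-fold lower number from compound 1 to compound 2 (0.25 log units; within the scatter), obtained with 1,3-thiazol-5-yl in place of 5-bromopyridin-3-yl on a carbonyl carbon, so the two values sit within the scatter of each other and no order between them can be read.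

Compound 3 `COc1cncc(C(=O)NC2(C(=O)N[C@H](C)c3ccc(-n4nc(Cl)c5ccccc54)cc3F)CC2)c1` differs from compound 1 in one place: methoxy in place of bromo on an aromatic carbon. Among the compounds with values here, no measured step touches this exact change; the one step on record swapped the whole ring and stayed within the scatter. On that basis the step to compound 3 is expected to stay small, with a 1.4-fold lower number from compound 1 to compound 3 (0.14 log units; within the scatter) as the estimate. In this assay compound 3 is therefore expected to give about 5.5 h, within a range from 2.5 h to 11 h.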

Compound 3, half-life: 2.3 h
Compound 3: middle estimate off by 2.4-fold (0.38 log units), on the high side; measured number outside the range, below it.
By their numbers in this assay, from the lowest: compounds 3, 2 and 1 (each within the scatter of the next, the first and the last beyond it).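

In this assay, going by these compounds alone, replacing bromo with methoxy on the six-membered aromatic ring gives a 3.3-fold lower number from compound 1 to compound 3 (0.52 log units; beyond the scatter) and is the first step here to pass beyond the scatter, which shows that this single substituent can shift the half-life while the ring itself stays the same. Yet with the 5-methoxypyridin-3-yl amide, the result cannot be separated from the 1,3-thiazol-5-yl amide, as a 1.9-fold lower number from compound 2 to compound 3 (0.27 log units; within the scatter) shows, so only compound 1 and compound 3 stand apart. Nothing at hand explains the step.

The compounds shown do not tell whether losing bromo or gaining methoxy drives the shift. As far as these compounds go, how chloro, ethoxy or an amine at the same place would read in this assay also remains open.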